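Dinitrophenyl in Place of Ethoxyphenyl on a Triazole Nitrogen

The compounds below may be only part of what the source reports. "The series", "measured", "known", "first", "only" and "open" are said of these compounds alone.

Measured compounds:
compound 1 `Cc1ccc(-n2nncc2CN2C(=O)C3(C(C#N)=C(N)Oc4c3c3nc5ccccc5nc3c3ccccc43)c3ccccc32)c(C)c1`: > 50000 nM
compound 2 `CCOc1ccccc1-n1nncc1CN1C(=O)C2(C(C#N)=C(N)Oc3c(N)cc4nc5ccccc5nc4c32)c2ccccc21`: > 50000 nM

In a functional assay on MCF7 cells (Homo sapiens) for antiproliferative activity, read by MTT assay, with a stated time of 48 h (on this read-out higher numbers stand for weaker inhibition and lower numbers for stronger inhibition), compound 1 gives only a limit, > 50000 nM. Compound 2 likewise gives only a limit in this assay, > 50000 nM. So compound 2 stands at the limit of > 50000 nM in this assay, at which 2 of the 2 values shown sit, with no number to rank it. Compound 3 `N#CC1=C(N)Oc2c(N)cc3nc4ccccc4nc3c2C12C(=O)N(Cc1cnnn1-c1ccc([N+](=O)[O-])cc1[N+](=O)[O-])c1ccccc12` carries 2,4-dinitrophenyl in place of 2-ethoxyphenyl on an aromatic nitrogen. With both known values sitting at the limit, no step size beyond the scatter can be expected for a number no higher from compound 2 to compound 3 (the limit leaves the size open). Compound 3 is therefore estimated at 50000 nM in this assay, within 20000 nM to 100000 nM, most probably again as a limit.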

Compound 3, half-maximal inhibitory concentration: 20900 nM
Compound 3: middle estimate off by 2.4-fold (0.38 log units), on the high side, and the stated range covers the measured number.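

In this assay, 2,4-dinitrophenyl in place of 2-ethoxyphenyl on the aromatic nitrogen gives an at least 2.3-fold lower number from compound 2 to compound 3 (0.37 log units; beyond the scatter), so the group at this position can bring the read-out off the limit on the core shared by these two compounds. Going by these compounds alone, compound 3, at 20900 nM, is the first of the compounds to give an actual number. The value of compound 2 is a limit, so the full size of the step stays open: the limit of > 50000 nM in this assay, at which 2 of the 3 values shown sit.

On these data alone, it remains open whether a phenyl ring with a single nitro group would give a similar number. The same holds for an aminophenyl or a simple methyl group at this position.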